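Working notes on tolerated concentration: from compound 1 to compound 4

This account rests on a few compounds, and the source may have more. Where it says the series, first, only, none or still open, it means among the compounds named here.

The series is followed in a functional assay on Huh7.5.1 cells (Homo sapiens) for cytotoxicity, read by MTT assay, with a stated time of 72 h; a higher number here means that more compound is tolerated, a lower number that less compound is tolerated. Compound 1, `C=c1[nH]c(=O)/c(=C/c2ccc(OC)c(OC)c2)[nH]c1=O`, gives > 20000 nM in this assay, and this is a limit of the assay rather than a number. Compound 2, `C=c1[nH]c(=O)/c(=C/c2ccc(C)cc2)[nH]c1=O`, likewise reaches only a limit, > 20000 nM. Compound 3, `C=CC(C)(C)c1[nH]c2ccccc2c1/C=c1\[nH]c(=O)c(=C)[nH]c1=O`, also stops at a limit, > 20000 nM. Within the data shown here, compound 1 therefore stands exactly where every compound measured so far stands, namely at the limit of > 20000 nM in this assay, at which 3 of the 3 values shown sit. Among the measured compounds shown here, no pair among the measured compounds differs in a single place, so no step in this assay is known; the three values merely show the same limit, and nothing in them orders the compounds.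

Compound 4, `C=c1[nH]c(=O)/c(=C/c2cc(OC)c(OC)c(OC)c2)[nH]c1=O`, is the next to be measured. Compared with compound 1 it carries methoxy in place of hydrogen on an aromatic carbon. Compound 1 sits at a limit of > 20000 nM. For the measured compounds named here, with no measured step to give a direction, the change from compound 1 to compound 4 is expected to be none beyond the scatter in this assay, the most likely outcome being that compound 4 again returns only a limit. Compound 4 is accordingly expected to give about 25000 nM, within 15000 nM to 60000 nM. The expected step is then a step that the limit leaves unreadable from compound 1 to compound 4.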

Compound 4, half-maximal cytotoxic concentration: > 20000 nM
Compound 4 gave a limit, no number; the forecaster's own chance of this, stated with the estimate: 85%; the middle value lies beyond the limit too.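

Compound 1 and compound 4 both stop at a limit, so no step can be read for methoxy in place of hydrogen on an aromatic carbon: the limit of > 20000 nM in this assay, at which 4 of the 4 values shown sit.

The compounds shown leave open where the tolerated concentration of each actually lies, and whether any change to the shared core would give a readable number.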